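The compounds below may be only part of what the source reports. "The series", "measured", "known", "first", "only" and "open" are said of these compounds alone.

Measured so far:
compound 1 `COc1cc(-c2cc(/C=C/C(=O)c3ccc(N)cc3)[nH]n2)cc(OC)c1OC`, -20% 
compound 2 `COc1cc(-c2cc(/C=C/C(=O)c3ccc(Cl)c(Cl)c3)[nH]n2)cc(OC)c1OC`, 47% 

In a functional assay on SW-620 cells (Homo sapiens) for cytotoxicity, read by sulforhodamine B assay, with a stated time of 48 h, tested at 10 uM (a lower number here means a stronger effect, a higher number a weaker effect of the compound at the concentration tested), compound 2 holds the highest of the two numbers, with compound 1 the lower one. Compound 3 `COc1ccc(C(=O)/C=C/c2cc(-c3cc(OC)c(OC)c(OC)c3)n[nH]2)cc1OC` differs from compound 2 by 3,4-dimethoxyphenyl in place of 3,4-dichlorophenyl on a carbonyl carbon. Going by the values given here, the one measured step at this position, a number 67 percentage points higher from compound 1 to compound 2 (beyond the scatter), shows that the group on the carbonyl carbon can move this read-out strongly. Among the compounds with values here, no step joins 3,4-dichlorophenyl to 3,4-dimethoxyphenyl directly, so the direction is uncertain. Compound 3 is estimated at 20%, within -15% to 55%. That estimate would mean a step of a number 27 percentage points lower from compound 2 to compound 3 (beyond the scatter), expected downward.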

Compound 3, a percentage reported as activity, at one concentration (the size of the read-out at that concentration, not a potency): -77%
Beside the measured number, compound 3's estimate is 97 percentage points above it, and the stated range ends above it.
By their numbers in this assay, from the lowest: compound 3; then compound 1; then compound 2.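

In this assay, the 3,4-dimethoxyphenyl group on the carbonyl carbon gives the strongest effect of the three compounds, with a number 124 percentage points lower from compound 2 to compound 3 (beyond the scatter) and a number 57 percentage points lower from compound 1 to compound 3 (beyond the scatter) both beyond the scatter. The earlier step had shown only that this position can weaken the effect relative to the 4-aminophenyl compound; it can also strengthen it. The 3,4-dichlorophenyl and 3,4-dimethoxyphenyl groups also lie far apart, so their shared placement alone does not set the read-out. Nothing available explains this difference. As far as these compounds go, whether a 3,4,5-trimethoxyphenyl or a pyridyl group on the carbonyl carbon would go further remains open.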